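Adding a methoxy to a weakly active compound

This account rests on a few compounds, and the source may have more. Where it says the series, first, only, none or still open, it means among the compounds named here.

In a functional assay on FM3A cells (Mus musculus) for antiproliferative activity, with a stated time of 48 h (a higher number here means a weaker inhibitor, a lower number a stronger inhibitor), compound 1 (`C=C(Br)C(=O)Nc1ccc(C(=O)/C=C/c2cccc(OC)c2OC)cc1`) gives 550 nM. Compound 2 (`COc1cccc(/C=C/C(=O)c2ccc(N)cc2)c1`) gives 45000 nM, and compound 3 (`COc1ccccc1/C=C/C(=O)c1ccc(N)cc1`) gives 25000 nM, a value within the scatter of compound 2 and far higher than that of compound 1. Compound 4 (`COc1cccc(/C=C/C(=O)c2ccc(N)cc2)c1OC`) follows from compound 3 with methoxy in place of hydrogen on an aromatic carbon, ortho to a methoxy group: methoxy in place of hydrogen on an aromatic carbon. Among the measured compounds shown here, no measured step shows this change. Compound 2 at 45000 nM and compound 3 at 25000 nM lie within the scatter, so no step beyond the scatter is expected in this assay. The expected 1.2-fold higher number from compound 3 to compound 4 (0.08 log units; within the scatter) is small. Compound 4 is estimated at 30000 nM, with an expected range of 10000 nM to 80000 nM.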

Compound 4, half-maximal inhibitory concentration: 29000 nM
Beside the measured number, compound 4's estimate is 1.0-fold (0.01 log units) above it; the measured number falls inside the stated range.
By their numbers in this assay, from the lowest: compound 1; then compounds 3, 4 and 2 (each within the scatter of the next).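

In this assay, methoxy in place of hydrogen on this aromatic carbon, ortho to a methoxy group, shows no effect beyond the scatter against either compound carrying one methoxy (a 1.2-fold higher number from compound 3 to compound 4 (0.06 log units; within the scatter); a 1.6-fold lower number from compound 2 to compound 4 (0.19 log units; within the scatter)). The large step lies at the other place, hydrogen in place of (1-bromoethenyl)carbonyl on the nitrogen (a 53-fold higher number from compound 1 to compound 4 (1.72 log units; beyond the scatter)). No evidence given here bears on this result. Still open, from the compounds shown here alone, is whether a hydroxyl or a chlorine at this carbon would read differently, and whether the second methoxy matters once the (1-bromoethenyl)carbonyl is present.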